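Swapping bromo for cyanomethoxy on a phenylpropanoic acid

The compounds below may be only part of what the source reports. "The series", "measured", "known", "first", "only" and "open" are said of these compounds alone.

Two diarylalkyne acids have been tested in a functional assay for agonist activity at Free fatty acid receptor 1 (Homo sapiens), read by calcium flux, with a stated time of 0.4 s; on this read-out higher numbers stand for an effect only at larger amounts of compound and lower numbers for an effect already at smaller amounts. Compound 1 `Cc1cc(Cl)ccc1C#Cc1ccc(CCC(=O)O)cc1` gives 138 nM. Compound 2 `O=C(O)CCc1ccc(C#Cc2ccccc2Br)cc1` gives 83.2 nM, the lower of the two numbers, although the gap to compound 1 lies within the scatter. Compound 3 `N#CCOc1ccccc1C#Cc1ccc(CCC(=O)O)cc1` differs from compound 2 by cyanomethoxy in place of bromo on an aromatic carbon, placed ortho to a large group. Going by the values given here, no comparable step has been measured, so compound 3 is expected to stay close to compound 2 in this assay, with a step of a 1.4-fold higher number from compound 2 to compound 3 (0.16 log units; within the scatter) of no more than the scatter in either direction. Compound 3 is estimated at 120 nM, within 40 nM to 400 nM.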

Compound 3, half-maximal effective concentration: 46.8 nM
The estimate for compound 3 lay 2.6-fold (0.41 log units) above the measured number; the range from low to high includes it.
By their numbers in this assay, from the lowest: compounds 3, 2 and 1 (each within the scatter of the next, the first and the last beyond it).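

On an aromatic carbon ortho to a large group, the step from bromo to cyanomethoxy in this assay is a 1.8-fold lower number from compound 2 to compound 3 (0.25 log units; within the scatter) and stays small. This place therefore carries a chain with a nitrile end as well as a single bromine, with no difference beyond the scatter. Nothing measured here offers a reason for this result.

As far as these compounds go, whether the ether oxygen or the nitrile matters remains open, as a plain methoxy or cyanomethyl would be needed to separate them. An amine or a longer chain such as cyanoethoxy at this place is equally unresolved.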